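A few compounds are considered here, and "the series" means these few. Any claim that something is new, unique, unknown or untested is made for them only; others in the source may bear on it.

Working notes on the series, read in an in vitro ADME assay on microsomes from liver (Homo sapiens) for metabolic stability; on this read-out lower numbers stand for slow clearance and higher numbers for fast clearance. Within the data shown here, compound 3 (`CSc1nc2nc(C)cc(Nc3ccc(S(F)(F)(F)(F)F)cc3)n2n1`) gives 22.4 mL.min-1.g-1, the only actual number so far. Compound 1 (`Cc1cc(Nc2ccc(C(F)(F)F)cc2)n2nc(CCO)nc2n1`) gives < 5 mL.min-1.g-1, which is a limit. Compound 2 (`Cc1cc(Nc2ccc(C(F)(F)F)cc2)n2nc(C3CC3)nc2n1`) gives < 5 mL.min-1.g-1, also a limit. Among the measured compounds shown here, the one measured step is a step that the two limits leave unreadable from compound 1 to compound 2, and it does not cover the present change. Compound 4 (`CSc1nc2nc(C)cc(Nc3ccc(C(F)(F)F)cc3)n2n1`) differs from compound 3 by a group of 4 heavy atoms (1 carbon, 3 fluorine; no ring) in place of a group of 6 heavy atoms (5 fluorine, 1 sulfur; no ring), on an aromatic carbon, with trifluoromethyl entering para to a large group. Compounds 1 and 2 also carry trifluoromethyl, and they offer only (the limit of < 5 mL.min-1.g-1 in this assay, at which 2 of the 3 values shown sit). On that indirect basis a moderate fall towards slower clearance is expected, given as a 2.2-fold lower number from compound 3 to compound 4 (0.35 log units; beyond the scatter). For compound 4 the estimate is 10 mL.min-1.g-1, with an expected range of 5 mL.min-1.g-1 to 20 mL.min-1.g-1.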

Compound 4, intrinsic clearance in microsomes: 18.7 mL.min-1.g-1
Estimate against measurement, compound 4: 1.9-fold (0.27 log units) below; measured number inside the range.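

In this assay, trifluoromethyl in place of the group of 6 heavy atoms gives a 1.2-fold lower number from compound 3 to compound 4 (0.08 log units; within the scatter), so the two groups cannot be told apart at this position. Methylsulfanyl on the other aromatic carbon gives an at least 3.7-fold higher number from compound 2 to compound 4 (0.57 log units; beyond the scatter) and an at least 3.7-fold higher number from compound 1 to compound 4 (0.57 log units; beyond the scatter), so the readable steps so far come from that place. Both steps start from a limit of the assay, so their full size stays unknown: the limit of < 5 mL.min-1.g-1 in this assay, at which 2 of the 4 values shown sit.

As far as these compounds go, it remains open whether a nitrile or a carboxylic acid at the trifluoromethyl position would move the number. An amine in place of methylsulfanyl is also untested among the compounds shown.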